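Methoxy for Vinyl on a Sulfonamide Aryl Ring

The source may hold more compounds than are shown below. What is called first, only, known or untested is meant among the compounds shown, and "the series" means these compounds.

Of the compounds shown here, two from this series have been tested in an ADME assay on HEK293 cells (Homo sapiens) for cytotoxicity, read by resazurin assay, with a stated time of 48 h; on this read-out higher numbers stand for lower toxicity in this test and lower numbers for higher toxicity in this test. Compound 1 `C=Cc1ccc(S(=O)(=O)Nc2ccc3oc(-c4ccccc4)nc3c2)cc1` gives 53000 nM in this assay, and compound 2 `O=[N+]([O-])c1cc(S(=O)(=O)Nc2ccc(-c3nc4ccccc4o3)cc2)ccc1Cl` gives 85000 nM. Compound 1 has the lower of the two numbers, but the gap to compound 2 lies within the scatter, so the two compounds cannot be told apart on this read-out.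

Compound 3 `COc1ccc(S(=O)(=O)Nc2ccc3oc(-c4ccccc4)nc3c2)cc1` has not been tested. It differs from compound 1 in one place: methoxy in place of vinyl on an aromatic carbon. For the measured compounds named here, no pair of measured compounds in this set shows the effect of such a change, so there is nothing to set the size of the step from. With both measured compounds sitting close together, the step of a 1.1-fold higher number from compound 1 to compound 3 (0.05 log units; within the scatter) is expected to stay within the scatter, in no particular direction. Compound 3 is therefore estimated at 60000 nM in this assay, with a range from 25000 nM to 150000 nM.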

Compound 3, half-maximal cytotoxic concentration: 91000 nM
The estimate for compound 3 lay 1.5-fold (0.18 log units) below the measured number; the range from low to high includes it.
By their numbers in this assay, from the lowest: compounds 1, 2 and 3 (each within the scatter of the next).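

For the compounds shown here, this is the first step that can be read at this position. In this assay the change from 4-vinylphenyl to 4-methoxyphenyl, on an aromatic carbon para to a large group, gives a 1.7-fold higher number from compound 1 to compound 3 (0.23 log units; within the scatter) on the core of compound 1. Here the double bond outside aromatic rings gives way to an oxygen that counts as a hydrogen-bond acceptor, and the read-out still does not separate the two compounds beyond the scatter.

From the compounds shown here alone, whether an amine, a carboxylic acid or a longer chain such as ethoxy at this position would give a step beyond the scatter stays open. So does whether methoxy in place of vinyl would give a similar step on another core. Nothing at hand offers an explanation for this result.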